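Cytotoxicity of a substituted benzylimidazole series on mouse fibroblasts

The source may hold more compounds than are shown below. What is called first, only, known or untested is meant among the compounds shown, and "the series" means these compounds.

Compound 1 `c1ccc(-c2ccc(Cn3cncc3CNc3ccc(-c4onc5ccccc45)c(-c4ccccc4)c3)cc2)cc1` — in a toxicity assay on NIH3T3 cells (Mus musculus) for cytotoxicity, read by resazurin assay (on this read-out lower numbers stand for an effect already at smaller amounts and higher numbers for an effect only at larger amounts of compound), compound 1 gives > 10000 nM, a limit of the assay.
Compound 2 `COC(=O)c1ccc(NCc2cncn2Cc2ccc(N)cc2)cc1-c1ccccc1` — compound 2 gives > 10000 nM, again a limit.
Compound 3 `O=C(c1ccc(NCc2cncn2Cc2ccc(-c3ccccc3)cc2)cc1-c1ccccc1)N1CCCCC1` — compound 3 gives > 1000 nM, also a limit.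

All three measured values are limits, so compound 2 stands at the upper edge of what this assay reports, as do two of the three values (the limit of > 10000 nM in this assay, at which 2 of the 3 values shown sit); the third sits at the limit of > 1000 nM in this assay, at which 1 of the 3 values shown sits. Among the compounds with values here, the single step between measured compounds, a step that the two limits leave unreadable from compound 1 to compound 3, is unreadable from its two limits. Compound 4 `COC(=O)c1ccc(NCc2cncn2Cc2cccc(C(C)(C)C)c2)cc1-c1ccccc1` differs from compound 2 by 3-(tert-butyl)phenyl in place of 4-aminophenyl on a saturated chain carbon bound to an aromatic nitrogen. Within the data shown here, no measured step bears on this change, so no shift beyond the scatter is expected: the estimated step that the limit leaves unreadable from compound 2 to compound 4 is flat. Compound 4 is expected to give 15000 nM, with a range from 5000 nM to 50000 nM, most likely as a limit.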

Compound 4, half-maximal effective concentration: > 1000 nM
Compound 4 ended at the assay's limit (the forecaster's own chance of this, stated with the estimate: 85%); the middle value does not contradict the limit.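

Compound 2 and compound 4 both give only limits in this assay, so no step can be read between them. The compounds shown leave open at what concentration any of them would harm these cells.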